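Swapping the aryl group on the amine nitrogen

The compounds below may be only part of what the source reports. "The series", "measured", "known", "first", "only" and "open" are said of these compounds alone.

Measured so far:
- compound 1, `CCc1ccc(NC2=CC(=O)c3c(nc4n3[C@H]3OC[C@@H](O)[C@H]3OC4)C2=O)cc1`: 6510 nM
- compound 2, `O=C1C=C(Nc2ccccc2F)C(=O)c2c1nc1n2[C@H]2OC[C@@H](O)[C@H]2OC1`: 5120 nM

Both compounds share a core and differ only in the aromatic group hanging on the amine nitrogen. In a functional assay on HeLa cells (Homo sapiens) for inhibition, read by sulforhodamine B assay (on this read-out higher numbers stand for weaker inhibition and lower numbers for stronger inhibition), compound 2 gives 5120 nM, the lowest of the two numbers, though its gap to compound 1 lies within the usual scatter, so the two cannot be ranked against each other.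

Compound 3, `Cc1ccc(NC2=CC(=O)c3nc4n(c3C2=O)[C@H]2OC[C@@H](O)[C@H]2OC4)cc1`, has not yet been measured. The change from compound 2 is 4-methylphenyl in place of 2-fluorophenyl on an amine nitrogen. For the measured compounds named here, no comparable step between measured compounds is at hand, and compound 1, which also carries an alkyl-substituted phenyl on the same nitrogen, sits within the scatter of compound 2. The expected step from compound 2 to compound 3 in this assay is therefore a 1.2-fold higher number from compound 2 to compound 3 (0.07 log units; within the scatter), none beyond the scatter in either direction. Compound 3 is estimated at 6000 nM, in the range 2500 nM to 14000 nM.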

Compound 3, half-maximal inhibitory concentration: 3860 nM
Compound 3: the middle estimate sits 1.6-fold (0.19 log units) above what was measured; low and high end bracket the measured number.
By their numbers in this assay, from the lowest: compounds 3, 2 and 1 (each within the scatter of the next).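

In this assay, putting 4-methylphenyl in place of 2-fluorophenyl on the amine nitrogen gives a 1.3-fold lower number from compound 2 to compound 3 (0.12 log units; within the scatter), so this swap does not separate the two compounds. With compound 3, three different substituted phenyl groups have been seen at this position, and each number lies within the scatter of the next, so these three groups cannot be ranked. No measurement at hand bears on the reason for this result.

As far as these compounds go, it remains open whether a group of a different kind on this nitrogen, such as a pyridine ring, a plain alkyl chain or a phenyl carrying a carboxylic acid, would move the number beyond the scatter. The compounds shown also leave open how 4-fluorophenyl or 2-methylphenyl would read here.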